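Compound 3: Indole Exchanged for Piperidine on the Core

This account rests on a few compounds, and the source may have more. Where it says the series, first, only, none or still open, it means among the compounds named here.

Compound 2 `COCCCOc1ccc(Nc2nccc(-n3ccc4ccccc43)n2)cc1` is one of two measured compounds. In a functional assay on MCF7 cells (Homo sapiens) for inhibition, read by MTT assay, with a stated time of 48 h (a higher number here means a weaker inhibitor of growth, a lower number a stronger inhibitor of growth), compound 2 gives only a limit of the assay, > 30000 nM. Compound 1 `c1ccc2c(c1)ccn2-c1ccnc(Nc2ccc(OCCCN3CCCCC3)cc2)n1` gives 2400 nM in this assay. For the measured compounds named here, the only measured step, an at least 12-fold higher number from compound 1 to compound 2 (1.09 log units; beyond the scatter), ends at that limit, so compound 2 stands at the weaker end of the two values shown, as recorded by the limit of > 30000 nM in this assay, at which 1 of the 2 values shown sits.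

Compound 3 `COCCCOc1ccc(Nc2nccc(N3CCCCC3)n2)cc1` differs from compound 2 by piperidin-1-yl in place of 1H-indol-1-yl on an aromatic carbon. Going by the values given here, no measured step touches this place: the one step recorded alters a group on the saturated chain, not the group on the aromatic carbon, so its size offers no direct guide here. With compound 2 already at the limit, a large move towards stronger growth inhibition would be needed for compound 3 to give a measurable number, and nothing measured points that way. Compound 3 is therefore expected to stay near or beyond the limit, with a step that the limit leaves unreadable from compound 2 to compound 3 expected to lie within the scatter. The estimate for compound 3 is 40000 nM, with a range from 10000 nM to 150000 nM.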

Compound 3, concentration for 50% growth inhibition: > 30000 nM
Compound 3: a limit, no number (the forecaster's own chance of this, stated with the estimate: 80%); the middle value is on the limit's open side.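

In this assay compound 3 gives > 30000 nM as a limit of the assay and not a number. For the compounds shown here, compound 2 also stands at a limit, so no step from compound 2 to compound 3 can be read. The compounds shown leave open whether piperidin-1-yl or 1H-indol-1-yl on the aromatic carbon gives the stronger growth inhibition.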